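Chloro for fluoro on the benzimidazole of compound 3

The source may hold more compounds than are shown below. What is called first, only, known or untested is meant among the compounds shown, and "the series" means these compounds.

Three members of the series share one core. Compound 1 `COc1ccc2[nH]c(=O)c(-c3nc4cc(Cl)ccc4[nH]3)cc2c1` bears a methoxy on one ring and a chloro on the other. In a functional assay on BEL-7404 cells for cytotoxicity against BEL-7404 tumor cell line (Homo sapiens), read by MTT assay, with a stated time of 48 h (a lower number here means a stronger inhibitor, a higher number a weaker inhibitor), compound 1 gives only the assay limit > 100000 nM, not a number. Compound 2 `Cc1ccc2[nH]c(=O)c(-c3nc4ccccc4[nH]3)cc2c1` carries a methyl instead of the methoxy and no halogen. In this assay compound 2 likewise reaches only the limit > 100000 nM. Compound 3 `Cc1ccc2[nH]c(=O)c(-c3nc4cc(F)ccc4[nH]3)cc2c1` adds a fluoro to compound 2. In this assay compound 3 also stops at the limit > 100000 nM. Compound 3 therefore stands at the edge of what the numbers can show: every value shown sits at the limit of > 100000 nM in this assay, at which 3 of the 3 values shown sit, and the step that the two limits leave unreadable from compound 2 to compound 3 cannot be read in size or direction. Compound 4 `Cc1ccc2[nH]c(=O)c(-c3nc4cc(Cl)ccc4[nH]3)cc2c1` differs from compound 3 by chloro in place of fluoro on an aromatic carbon. Among the compounds with values here, no measured step bears on this change with a readable size; the only neighbouring step, fluoro entering, is hidden by the limit, and compound 1, which already carries the chloro, also sits at the limit. Compound 4 is thus expected to remain at or close to the limit, with an expected step that the limit leaves unreadable from compound 3 to compound 4 not beyond the scatter. Compound 4 is estimated at 150000 nM, within 50000 nM to 500000 nM, most likely reported as a limit again.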

Compound 4, half-maximal inhibitory concentration: 39000 nM
Compound 4: middle estimate off by 3.8-fold (0.59 log units), on the high side, outside the stated range (below it).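

Chloro is the only group at this aromatic carbon that brings the series to a readable value: chloro in place of fluoro gives an at least 2.5-fold lower number from compound 3 to compound 4 (0.40 log units; beyond the scatter), and chloro in place of hydrogen gives an at least 2.5-fold lower number from compound 2 to compound 4 (0.40 log units; beyond the scatter). The chloro does not give a readable value on every core in this assay, and the group on the other ring also matters: compound 1 carries the same chloro with a methoxy, and methyl in place of that methoxy gives an at least 2.5-fold lower number from compound 1 to compound 4 (0.40 log units; beyond the scatter). All three sizes are minimum sizes, the step for fluoro in place of hydrogen cannot be read, and compound 4 alone holds a number: the limit of > 100000 nM in this assay, at which 3 of the 4 values shown sit.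

As far as these compounds go, the true size of each step remains open, and so does whether the gain follows the size of the halogen, a question that a bromo or a trifluoromethyl at this carbon would address. Also open, from the compounds shown here alone, is whether an ethyl, an amine or a carboxylic acid in place of the methyl would keep, raise or lose the activity seen with the chloro.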